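Allyloxy in Place of Ethoxy on an Amine-Bearing Quinoline-Like Core

A few compounds are considered here, and "the series" means these few. Any claim that something is new, unique, unknown or untested is made for them only; others in the source may bear on it.

Measured compounds:
- compound 1 `C=CCOc1ccc2c(NCCN(C)C)ccnc2c1`: 860 nM
- compound 2 `CCOc1ccc2c(NCCN(C)C)ccnc2c1`: 2570 nM
- compound 3 `CCOc1ccc2c(NCCCN(C)C)ccnc2c1`: 3380 nM

All three were tested in a functional assay on HCT-116 cells (Homo sapiens) for cytotoxicity, read by MTT assay, with a stated time of 48 h; a higher number here means a weaker inhibitor, a lower number a stronger inhibitor. In this assay compound 1 gives 860 nM, compound 2 gives 2570 nM, and compound 3 gives 3380 nM.

Two structural changes connect them. From compound 2 to compound 1 the change is vinyl in place of methyl on a saturated chain carbon bound to an oxygen on an aromatic ring, and the step it made was a 3.0-fold lower number from compound 2 to compound 1 (0.48 log units; beyond the scatter). From compound 2 to compound 3 the change is (dimethylamino)methyl in place of dimethylamino on a saturated chain carbon, two bonds along the chain from a nitrogen on an aromatic ring, and the step it made was a 1.3-fold higher number from compound 2 to compound 3 (0.12 log units; within the scatter).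

Compound 4 `C=CCOc1ccc2c(NCCCN(C)C)ccnc2c1` has not yet been measured. It differs from compound 3 by vinyl in place of methyl on a saturated chain carbon bound to an oxygen on an aromatic ring, the same change as from compound 2 to compound 1, made at the same place. The two cores differ by the change from compound 2 to compound 3, so compound 4 stands to compound 3 as compound 1 stands to compound 2.

Because the earlier step was a 3.0-fold lower number from compound 2 to compound 1 (0.48 log units; beyond the scatter), a step of similar size is expected from compound 3 to compound 4 in this assay, namely a 3.1-fold lower number from compound 3 to compound 4 (0.49 log units; beyond the scatter). This rests on a single pair, so the expectation is held loosely. On that basis compound 4 is estimated at 1100 nM, with a likely range from 500 nM to 2500 nM.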

Compound 4, half-maximal inhibitory concentration in the HCT-116 assay: 2100 nM
For compound 4 the middle estimate is 1.9-fold (0.28 log units) below the measured one; the measured number falls inside the stated range.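

Carried to the core of compound 3, allyloxy in place of ethoxy gives, in the HCT-116 assay, a 1.6-fold lower number from compound 3 to compound 4 (0.21 log units; within the scatter), and this step does not differ from the earlier one by more than repeated measurements can: the same change on two cores in the HCT-116 assay, a 3.0-fold lower number (0.48 log units; beyond the scatter) from compound 2 to compound 1 and a 1.6-fold lower number (0.21 log units; within the scatter) from compound 3 to compound 4, 1.9-fold (0.27 log units) apart, within the scatter of two such steps

The second change, (dimethylamino)methyl in place of dimethylamino, gives in the HCT-116 assay a 2.4-fold higher number from compound 1 to compound 4 (0.39 log units; beyond the scatter), and it too agrees with its counterpart on the ethoxy compounds: the same change on two cores in the HCT-116 assay, a 1.3-fold higher number (0.12 log units; within the scatter) from compound 2 to compound 3 and a 2.4-fold higher number (0.39 log units; beyond the scatter) from compound 1 to compound 4, 1.9-fold (0.27 log units) apart, within the scatter of two such steps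

The two changes are therefore consistent across these four compounds, but the allyloxy step lies beyond the scatter only from compound 2 to compound 1, so a real gain on the core of compound 3 is not shown, and a single pair of cores cannot establish how reliably the change carries over.

In a physicochemical assay for solubility (on this read-out lower numbers stand for lower solubility and higher numbers for higher solubility), compound 3 gives > 10000 ug/mL, which is a limit of the assay and not a number. In the physicochemical assay compound 4 gives > 10000 ug/mL, which is also a limit of the assay and not a number. In the physicochemical assay the step from compound 3 to compound 4 cannot be read, as both values are limits of the assay and not numbers: the limit of > 10000 ug/mL in the physicochemical assay, at which 2 of the 2 values shown sit.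

Still open, on these data alone, is how a propoxy group in place of allyloxy, or a diethylamino group in place of dimethylamino, would behave in the HCT-116 assay on either core.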